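The source may hold more compounds than are shown below. What is called first, only, known or untested is meant among the compounds shown, and "the series" means these compounds.

Measured compounds:
- compound 1 `Clc1cccc(-c2cc(-c3ccc(Cl)o3)cc(-c3cccs3)n2)c1` gives 42% in an assay on isolated protein for inhibition of DNA topoisomerase 1 (Homo sapiens), tested at 100 uM; a lower number here means a weaker effect, a higher number a stronger effect of the compound at the concentration tested
- compound 2 `Clc1cccc(-c2cc(-c3ccc(Cl)o3)cc(-c3ccsc3)n2)c1` gives 0% in this assay
- compound 3 `Clc1ccc(-c2cc(-c3ccco3)cc(-c3cccs3)n2)cc1` gives 2.7% in this assay

Among these three, compound 1 stands highest in this assay, with compound 3 nearest and compound 2 furthest. The new compound 4 `Clc1ccc(-c2cc(-c3ccco3)nc(-c3cccs3)c2)o1` is reached from compound 1 by a single change: furan-2-yl in place of 3-chlorophenyl on an aromatic carbon.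

For the measured compounds named here, only one measured step is recorded, a number 42 percentage points lower from compound 1 to compound 2 (beyond the scatter), and it concerns a different change at a different position, so it does not bear directly on the step to compound 4. Going by the values given here, compound 3, which carries a furan ring and another chlorophenyl pattern, shows a value far below that of compound 1, but no single-place step links the two. Among the compounds with values here, what the numbers do show is that compound 1 alone is well above the others, and that the one recorded change moved the read-out down by a large amount. Compound 4 is therefore expected to lie lower than compound 1, with the step of a number 27 percentage points lower from compound 1 to compound 4 (beyond the scatter) estimated as downward and beyond the scatter. The estimate for compound 4 in this assay is 15%, within the range 0% to 40%.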

Compound 4, a percentage reported as inhibition, at one concentration (the size of the read-out at that concentration, not a potency): 16%
Compound 4: middle estimate off by 1 percentage points, on the low side; measured number inside the range.
By their numbers in this assay, from the lowest: compounds 2 and 3 (each within the scatter of the next); then compound 4; then compound 1.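

In this assay, for the compounds shown here, furan-2-yl in place of 3-chlorophenyl on the aromatic carbon next to the ring nitrogen gives a number 26 percentage points lower from compound 1 to compound 4 (beyond the scatter) and so shows that this position, which no earlier step touched, also bears on the read-out. The change does not abolish it, since compound 4 still gives 16% with furan-2-yl in this place. Nothing available here gives a reason for this drop.

The compounds shown do not separate the part played by the chlorine from that of the ring carrying it, and a plain phenyl group would speak to that. Also open, on these data alone, are how an amine or a carboxylic acid on the ring at this position would read, and whether the same swap would behave alike alongside thiophen-3-yl.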